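Swapping the Ring on the Amine of Compound 1

A few compounds are considered here, and "the series" means these few. Any claim that something is new, unique, unknown or untested is made for them only; others in the source may bear on it.

compound 1 `N#Cc1cnc(NCc2cnccc2C(F)(F)F)cc1N[C@H]1C[C@H](O)C1`: 900 nM
compound 2 `N#Cc1cnc(NCc2cnccc2C(F)(F)F)cc1NCC1CCOCC1`: 400 nM

Among the compounds with values here, in an assay on isolated protein for inhibition of protein kinase C theta type (Homo sapiens), read by TR-FRET, with a stated time of 2 h (on this read-out lower numbers stand for stronger inhibition and higher numbers for weaker inhibition), compound 1 gives 900 nM, the higher of the two numbers measured so far, while compound 2 gives 400 nM. Within the data shown here, the single measured step, a 2.3-fold lower number from compound 1 to compound 2 (0.35 log units; beyond the scatter), was obtained by exchanging the 3-hydroxycyclobutyl for a different saturated ring on the same nitrogen on an aromatic ring.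

Compound 3 `CNC(=O)[C@H]1CC[C@@H](Nc2cc(NCc3cnccc3C(F)(F)F)ncc2C#N)CC1` differs from compound 1 in the same place: 4-(methylcarbamoyl)cyclohexyl in place of 3-hydroxycyclobutyl on a nitrogen on an aromatic ring. The step from compound 1 to compound 2 is the only one that bears on this change, and it was modest. A six-membered ring carrying a methylcarbamoyl group has no measured neighbour here, so any guess carries wide uncertainty. Compound 3 is expected to show a modest step toward a lower number, a 2.0-fold lower number from compound 1 to compound 3 (0.30 log units; within the scatter). The estimated value for compound 3 is 450 nM, within 150 nM to 1400 nM.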

Compound 3, half-maximal inhibitory concentration: 27 nM
Compound 3: middle estimate off by 17-fold (1.22 log units), on the high side, and the stated range ends above it.
By their numbers in this assay, from the lowest: compound 3; then compound 2; then compound 1.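

In this assay the 4-(methylcarbamoyl)cyclohexyl group brings a 33-fold lower number from compound 1 to compound 3 (1.52 log units; beyond the scatter) and also a 15-fold lower number from compound 2 to compound 3 (1.17 log units; beyond the scatter) on the same nitrogen. Both steps are large, whereas the earlier change gave only a 2.3-fold lower number from compound 1 to compound 2 (0.35 log units; beyond the scatter) and so hinted at little of what this position can do. Nothing measured here explains the gain.

The change replaces 3-hydroxycyclobutyl with 4-(methylcarbamoyl)cyclohexyl and alters the ring and its substituent at once, so the compounds shown cannot separate the part played by the six-membered ring from that of the methylcarbamoyl group. Plain cyclohexyl, or a cyclohexyl carrying a primary amide, a carboxylic acid or an amine in place of the methylcarbamoyl, would help to tell these parts apart.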